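The source may report more compounds than this note shows. Statements on the series, on what has been measured and on what is new or still open speak of the compounds shown alone.

Measured in a functional assay on NCI-H1299 cells (Homo sapiens) for antiproliferative activity, read by CCK-8 assay, with a stated time of 72 h; a lower number here means a stronger inhibitor, a higher number a weaker inhibitor:
- compound 1 `CCOc1cc(C(C)(C)C)ccc1C1=NC(c2ccc(Cl)cc2)C(c2ccc(Cl)cc2)N1C(=O)N1CCN(CCCCCC(=O)NO)CC1`: 9390 nM
- compound 2 `CCOc1cc(C(C)(C)C)ccc1C1=NC(c2ccc(Cl)cc2)C(c2ccc(Cl)cc2)N1C(=O)NCCCCCCC(=O)Nc1ccccc1N`: 17500 nM
- compound 3 `CCOc1cc(C(C)(C)C)ccc1C1=NC(c2ccc(Cl)cc2)C(c2ccc(Cl)cc2)N1C(=O)N1CCN(Cc2ccc(C(=O)NO)cc2)CC1`: 3000 nM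

Compound 3 holds the lowest of the three numbers, beyond the scatter from both others. Compound 4 `CCOc1cc(C(C)(C)C)ccc1C1=NC(c2ccc(Cl)cc2)C(c2ccc(Cl)cc2)N1C(=O)N1CCN(CCCCC(=O)NO)CC1` differs from it as follows: 3-(hydroxycarbamoyl)propyl in place of 4-(hydroxycarbamoyl)phenyl on a saturated chain carbon bound to an amine nitrogen in a ring. Here 3-(hydroxycarbamoyl)propyl stands in place of 4-(hydroxycarbamoyl)phenyl on a saturated chain carbon bound to an amine nitrogen in a ring.

Within the data shown here, one measured step bears on this: a 3.1-fold lower number from compound 1 to compound 3 (0.50 log units; beyond the scatter), a modest change with 4-(hydroxycarbamoyl)phenyl replacing 4-(hydroxycarbamoyl)butyl. The new change runs the opposite way, from aromatic ring to open chain, so a modest rise of similar size is expected in this assay. The expected change is a 3.0-fold higher number from compound 3 to compound 4 (0.48 log units; beyond the scatter). The estimated value for compound 4 is 9000 nM, with an expected range of 4000 nM to 20000 nM.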

Compound 4, half-maximal inhibitory concentration: 12900 nM
Estimate against measurement, compound 4: 1.4-fold (0.16 log units) below; measured number inside the range.
By their numbers in this assay, from the lowest: compound 3; then compounds 1, 4 and 2 (each within the scatter of the next).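

In this assay the aromatic linker now stands apart from two open chains rather than one: the step is a 4.3-fold higher number from compound 3 to compound 4 (0.63 log units; beyond the scatter) with 3-(hydroxycarbamoyl)propyl entering. Chain length does not register over this range, with a 1.4-fold higher number from compound 1 to compound 4 (0.14 log units; within the scatter) when one chain replaces the other. No measured evidence explains either step.

Open, as far as these compounds go, is whether a saturated cyclohexyl ring in place of the phenyl ring would match compound 3. From the compounds shown here alone, a longer chain, or a carboxylic acid in place of the hydroxycarbamoyl end, also remains open.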